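The source may hold more compounds than are shown below. What is called first, only, known or untested is meant among the compounds shown, and "the series" means these compounds.

Compound 1 `O=c1c2ccccc2ccn1[C@@H]1O[C@H](COP(=O)(O)OP(=O)(O)OP(=O)(O)O)[C@@H](O)[C@H]1O` gives 31 nM in a functional assay for agonist activity at P2Y purinoceptor 2 (Homo sapiens), read by FLIPR (a higher number here means that more compound is needed for the effect, a lower number that less compound is needed), the lowest of the three numbers in hand. Compound 2 `Cc1ccc2ccn([C@@H]3O[C@H](COP(=O)(O)OP(=O)(O)OP(=O)(O)O)[C@@H](O)[C@H]3O)c(=O)c2c1` gives 148 nM and compound 3 `Cc1cccc2ccn([C@@H]3O[C@H](COP(=O)(O)OP(=O)(O)OP(=O)(O)O)[C@@H](O)[C@H]3O)c(=O)c12` gives 85 nM in this assay. Both measured steps, a 4.8-fold higher number from compound 1 to compound 2 (0.68 log units; beyond the scatter) and a 2.7-fold higher number from compound 1 to compound 3 (0.44 log units; beyond the scatter), raised the number beyond the scatter, each a modest rise for a methyl entering on an aromatic carbon of the shared core. Compound 4 `O=c1c2ccc(F)cc2ccn1[C@@H]1O[C@H](COP(=O)(O)OP(=O)(O)OP(=O)(O)O)[C@@H](O)[C@H]1O` differs from compound 1 by fluoro in place of hydrogen on an aromatic carbon. Among the compounds with values here, no fluoro step has been measured, so the methyl steps are the only precedent; a rise in this assay smaller than those, perhaps not beyond the scatter, is expected. The expected step is a 1.6-fold higher number from compound 1 to compound 4 (0.21 log units; within the scatter). Compound 4 is estimated at 50 nM, with a range from 20 nM to 150 nM.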

Compound 4, half-maximal effective concentration: 77 nM
Beside the measured number, compound 4's estimate is 1.5-fold (0.19 log units) below it; the range from low to high includes it.
By their numbers in this assay, from the lowest: compound 1; then compounds 4, 3 and 2 (each within the scatter of the next).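

Even fluoro, a single atom with no hydrogen-bond donors or acceptors, on this carbon of the six-membered aromatic ring raises the number in this assay beyond the scatter, with a 2.5-fold higher number from compound 1 to compound 4 (0.40 log units; beyond the scatter). This is the first non-carbon group shown on the ring, and, with the methyl steps, all three substitutions shown leave compound 1 with the lowest number. Nothing available explains this rise. Open, as far as these compounds go, is whether methyl on this same carbon would match fluoro, and whether chloro, methoxy or an amine here would raise the number further.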